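A few compounds are considered here, and "the series" means these few. Any claim that something is new, unique, unknown or untested is made for them only; others in the source may bear on it.

Two members of the series have numbers in a functional assay on NCI-H460 cells (Homo sapiens) for antiproliferative activity, read by MTT assay, with a stated time of 72 h; a lower number here means a stronger inhibitor, a higher number a weaker inhibitor. Compound 1 `Cn1ccc2c(Oc3ccc(NC(=O)c4cc5cccnc5n(-c5ccccc5)c4=O)cc3F)ccnc21` carries an unsubstituted phenyl on the aromatic nitrogen of the shared core; in this assay compound 1 gives 550 nM. Compound 2 `Cn1ccc2c(Oc3ccc(NC(=O)c4cc5cccnc5n(-c5ccc(Br)cc5F)c4=O)cc3F)ccnc21` differs from it only in the group on that nitrogen; in this assay compound 2 gives 3150 nM, the higher of the two numbers, so compound 2 is the weaker of the pair. Within the data shown here, the single measured step, a 5.7-fold higher number from compound 1 to compound 2 (0.76 log units; beyond the scatter), is the only guide to what substitution on this ring does.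

Compound 3 `Cn1ccc2c(Oc3ccc(NC(=O)c4cc5cccnc5n(-c5ccc(C(F)(F)F)cc5Cl)c4=O)cc3F)ccnc21` is not yet measured. Relative to compound 2 the change is 2-chloro-4-(trifluoromethyl)phenyl in place of 4-bromo-2-fluorophenyl on an aromatic nitrogen. Among the measured compounds shown here, no measured step compares two substituted phenyl groups with each other; the step from compound 1 to compound 2 shows only that going from the bare ring to a ring of this substitution type raised the number, and compound 3 stays within that type. The step from compound 2 to compound 3 is therefore expected to be small, a 1.1-fold higher number from compound 2 to compound 3 (0.05 log units; within the scatter), probably within the scatter. Compound 3 is expected to give about 3500 nM, with a range from 1200 nM to 10000 nM.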

Compound 3, half-maximal inhibitory concentration: 6010 nM
Beside the measured number, compound 3's estimate is 1.7-fold (0.23 log units) below it; measured number inside the range.
By their numbers in this assay, from the lowest: compound 1; then compounds 2 and 3 (each within the scatter of the next).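

In this assay, a 1.9-fold higher number from compound 2 to compound 3 (0.28 log units; within the scatter) means that the two substituted rings are not separated, even though 2-chloro-4-(trifluoromethyl)phenyl brings 11 heavy atoms to the aromatic nitrogen where 4-bromo-2-fluorophenyl brings 8. Against the bare phenyl, an 11-fold higher number from compound 1 to compound 3 (1.04 log units; beyond the scatter) is a large step, so both substituted phenyl groups now give higher numbers than phenyl, with no compound among the three going against this, and compound 1 remains the strongest of the three. No available evidence bears on why the numbers at this position fall as they do.

Each substituted ring differs from phenyl in two places at once, so the compounds shown do not tell which substituent, or whether the pair together, accounts for the steps away from compound 1. Also open, going by these compounds, is whether a phenyl carrying a single fluorine, a phenyl carrying an amine or a carboxylic acid, or a methyl in place of the whole ring would stay close to compound 1 or join compound 2 and compound 3.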